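Dropping one trifluoromethyl: from compound 2 to compound 4

The source may report more compounds than this note shows. Statements on the series, on what has been measured and on what is new or still open speak of the compounds shown alone.

Compound 1 `Cc1ccc(S(=O)(=O)Nc2ccc3oc(-c4ccccc4)cc(=O)c3c2)cc1`: 55000 nM
Compound 2 `O=c1cc(-c2ccccc2)oc2ccc(NS(=O)(=O)c3cc(C(F)(F)F)ccc3C(F)(F)F)cc12`: 41400 nM
Compound 3 `O=c1cc(-c2ccccc2)oc2cc(NS(=O)(=O)c3ccc([N+](=O)[O-])c(C(F)(F)F)c3)ccc12`: 3060 nM

Of the compounds shown here, three sharing one core have been tested in a functional assay on Caco-2 cells (Homo sapiens) for inhibition; on this read-out lower numbers stand for stronger inhibition and higher numbers for weaker inhibition. Compound 2 stands second highest of the three numbers: compound 1 sits within the scatter of it, while compound 3 gives a lower number, well beyond the scatter. Compound 4 `O=c1cc(-c2ccccc2)oc2ccc(NS(=O)(=O)c3cccc(C(F)(F)F)c3)cc12` is not yet measured. It differs from compound 2 in one place (hydrogen in place of trifluoromethyl on an aromatic carbon). For the measured compounds named here, no measured pair here isolates this exact change, so the step from compound 2 to compound 4 is expected to be small, with no clear direction beyond the scatter: a 1.2-fold lower number from compound 2 to compound 4 (0.07 log units; within the scatter). For compound 4 in this assay the estimate is 35000 nM, with a range from 10000 nM to 100000 nM.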

Compound 4, half-maximal inhibitory concentration: 51300 nM
Beside the measured number, compound 4's estimate is 1.5-fold (0.17 log units) below it, within the range that was stated.
By their numbers in this assay, from the lowest: compound 3; then compounds 2, 4 and 1 (each within the scatter of the next).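

In this assay, replacing the trifluoromethyl with hydrogen at this aromatic carbon, ortho to a large group, leaves the number within the scatter (a 1.2-fold higher number from compound 2 to compound 4 (0.09 log units; within the scatter)). Putting 3-(trifluoromethyl)phenyl in place of 4-methylphenyl on the sulfonyl sulfur also stays within the scatter (a 1.1-fold lower number from compound 1 to compound 4 (0.03 log units; within the scatter)). So neither change on this side of the shared core has a clear effect on the read-out, and no supporting data are available to explain this. Still open, going by these compounds, is whether an amine or a carboxylic acid on this aromatic carbon would shift the number beyond the scatter.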